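A few compounds are considered here, and "the series" means these few. Any claim that something is new, unique, unknown or untested is made for them only; others in the source may bear on it.

Of the compounds shown here, three have been measured in a functional assay on DU-145 cells (Homo sapiens) for cytotoxicity, in the presence of a further agent that is not named here; on this read-out higher numbers stand for weaker inhibition and lower numbers for stronger inhibition. Compound 1 `Cc1ccccc1-c1cc(-c2ccc(Cl)o2)cc(-c2ccsc2)n1` gives 24800 nM. Compound 2 `Clc1ccc(-c2cc(-c3ccc(Cl)o3)cc(-c3ccsc3)n2)cc1` gives 19500 nM, and compound 3 `Clc1ccc(-c2cc(-c3cccnc3)nc(-c3ccsc3)c2)o1` gives 21600 nM. The three share one core and differ only in the group that sits on one aromatic carbon of that core. Among the three numbers compound 3 lies closest to compound 2, with a 1.1-fold higher number from compound 2 to compound 3 (0.04 log units; within the scatter), and its step to compound 1, a 1.1-fold lower number from compound 1 to compound 3 (0.06 log units; within the scatter), is also within the scatter, so compound 3 cannot be set apart from either of the others on these numbers.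

Compound 4 `Clc1ccc(-c2cc(-c3ccsc3)nc(-c3ccccn3)c2)o1` has not yet been measured. It differs from compound 3 by pyridin-2-yl in place of pyridin-3-yl on an aromatic carbon; the two compounds are built from the same atoms, joined differently. Every measured step bears on this change, because each of them exchanges the group on this same aromatic carbon: a 1.3-fold lower number from compound 1 to compound 2 (0.10 log units; within the scatter), a 1.1-fold lower number from compound 1 to compound 3 (0.06 log units; within the scatter) and a 1.1-fold higher number from compound 2 to compound 3 (0.04 log units; within the scatter) swapped 2-methylphenyl, 4-chlorophenyl and pyridin-3-yl against one another, and none of them moved the number beyond the scatter. The exchange of pyridin-3-yl for pyridin-2-yl is a smaller alteration than any of those, so the expected step in this assay is no change at the digits printed from compound 3 to compound 4 (within the scatter), none beyond the scatter. Compound 4 is therefore estimated at 21600 nM, within a range from 9000 nM to 52000 nM.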

Compound 4, half-maximal inhibitory concentration: 10900 nM
Estimate against measurement, compound 4: 2.0-fold (0.30 log units) above; measured number inside the range.
By their numbers in this assay, from the lowest: compounds 4, 2, 3 and 1 (each within the scatter of the next, the first and the last beyond it).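

In this assay, this carbon next to the ring nitrogen now shows its first exchange beyond the scatter (a 2.3-fold lower number from compound 1 to compound 4 (0.36 log units; beyond the scatter)), though the step is modest, so the group placed here can shift the number to a small degree. The other two new steps do not get that far: shifting the nitrogen within the pyridine ring gives (a 2.0-fold lower number from compound 3 to compound 4 (0.30 log units; within the scatter)) and exchanging 4-chlorophenyl gives (a 1.8-fold lower number from compound 2 to compound 4 (0.25 log units; within the scatter)), so compound 4 is set apart from compound 1 alone, and pyridin-2-yl cannot be ranked against pyridin-3-yl or 4-chlorophenyl on these numbers. No measurement offered here gives a reason for the step from 2-methylphenyl to pyridin-2-yl.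

The compounds shown leave open whether pyridin-4-yl, or a phenyl ring carrying an amine or a carboxylic acid, would move the number on this carbon any further than pyridin-2-yl does. As far as these compounds go, all four compounds also keep the 5-chlorofuran-2-yl and thiophen-3-yl groups unchanged, so what an exchange at either of those two places would do to the number remains unknown.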